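Notes on the step from compound 3 to compound 4

A few compounds are considered here, and "the series" means these few. Any claim that something is new, unique, unknown or untested is made for them only; others in the source may bear on it.

Values in a functional assay on Raji cells (Homo sapiens) for cytotoxicity, with a stated time of 72 h; a lower number here means a stronger inhibitor, a higher number a weaker inhibitor:
- compound 1 `CCOC(=O)/C=C/C=C/C=C/c1ccc[nH]1`: > 10000 nM (a limit)
- compound 2 `CCOC(=O)/C=C/C=C/C=C/C=C/c1ccc[nH]1`: 4090 nM
- compound 3 `O=C(/C=C/C=C/C=C/c1ccc[nH]1)OCc1ccccc1`: > 10000 nM (a limit)

Compound 3 has no number in this assay and sits at the limit of > 10000 nM in this assay, at which 2 of the 3 values shown sit. Compound 4 `O=C(/C=C/C=C/C=C/C=C/c1ccc[nH]1)OCc1ccccc1` differs from compound 3 by 2-(1H-pyrrol-2-yl)ethenyl in place of 1H-pyrrol-2-yl on a double-bonded chain carbon bound to a double-bonded chain carbon, with 2-(1H-pyrrol-2-yl)ethenyl in place of 1H-pyrrol-2-yl. Within the data shown here, the one step worked out so far, a step that the two limits leave unreadable from compound 1 to compound 3, offers no size to carry over. Compound 1 reads > 10000 nM, which is a limit. Among the measured compounds shown here, compound 2 gives 4090 nM, the only number. On the strength of that single number for compound 2, a move towards a lower number in this assay is expected, though its size stays uncertain and a reading at the limit remains possible. The expected change is an at least 2.5-fold lower number from compound 3 to compound 4 (0.39 log units; beyond the scatter). For compound 4 the expected value is 4000 nM. The estimated range for compound 4 runs from 1200 nM to 10000 nM.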

Compound 4, half-maximal inhibitory concentration: 1400 nM
Estimate against measurement, compound 4: 2.9-fold (0.46 log units) above, within the range that was stated.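

In this assay, 2-(1H-pyrrol-2-yl)ethenyl in place of 1H-pyrrol-2-yl on a double-bonded chain carbon bound to a double-bonded chain carbon now has a readable direction with phenyl present: an at least 7.1-fold lower number from compound 3 to compound 4 (0.85 log units; beyond the scatter). With the 2-(1H-pyrrol-2-yl)ethenyl end held fixed, phenyl in place of methyl on a saturated chain carbon bound to an oxygen next to a carbonyl group gets its first readable size: a 2.9-fold lower number from compound 2 to compound 4 (0.47 log units; beyond the scatter). The first of these steps is only a bound, and the same phenyl-for-methyl change from compound 1 to compound 3 cannot be read: the limit of > 10000 nM in this assay, at which 2 of the 4 values shown sit.

As far as these compounds go, whether a still longer chain would move the number further in this assay stays open. Also open, from the compounds shown here alone, is whether a carboxylic acid or an amide in place of the ester would keep the value of compound 4 at 1400 nM.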